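Chloro-for-hydrogen step on the benzyl arm, two cores

The source may report more compounds than this note shows. Statements on the series, on what has been measured and on what is new or still open speak of the compounds shown alone.

Compound 1 `CC1=C(C(=O)Nc2ccc(F)cc2)C(c2ccc([N+](=O)[O-])cc2)N=C(SCc2ccccc2)N1` and compound 2 `CC1=C(C(=O)Nc2ccc(F)cc2)C(c2ccc([N+](=O)[O-])cc2)N=C(SCc2ccccc2Cl)N1` share one core; compound 3 `COc1ccc(C2N=C(SCc3ccccc3)NC(C)=C2C(=O)Nc2ccc(Br)cc2)cc1` and compound 4 `COc1ccc(C2N=C(SCc3ccccc3Cl)NC(C)=C2C(=O)Nc2ccc(Br)cc2)cc1` share another, and the difference between the two cores is not broken down here. In a functional assay on the whole organism (artery, strain albino) with Rattus norvegicus as the target, with a stated time of 300 min, at a dose of 10 mg/kg by the oral route (on this read-out higher numbers stand for more inhibition at the one dose given (going by the name of the read-out) and lower numbers for less inhibition), compound 1 gives 38.5% and compound 2 gives 18.5%. The change from compound 1 to compound 2 is chloro in place of hydrogen on an aromatic carbon, and it made a step of a number 20 percentage points lower from compound 1 to compound 2 (beyond the scatter). In this assay compound 3 gives 16.4%. The change from compound 3 to compound 4 is chloro in place of hydrogen on an aromatic carbon, the same change at the same place. Among the measured compounds shown here, the step from compound 3 to compound 4 is expected to be a number 8.4 percentage points lower from compound 3 to compound 4 (within the scatter), with wide uncertainty, because the one measured instance of this change on the other core is a number 20 percentage points lower from compound 1 to compound 2 (beyond the scatter) from a higher starting number. Compound 4 is expected in this assay at 8%, with a range from -5% to 22%.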

Compound 4, a percentage reported as inhibition, in the whole organism at one dose (the size of the read-out at that dose, not a potency): 17.9%
Compound 4: middle estimate off by 9.9 percentage points, on the low side; the range from low to high includes it.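

In this assay, the same change on the benzyl arm does not carry over from one core to the other: the same change on two cores in this assay, a number 20 percentage points lower (beyond the scatter) from compound 1 to compound 2 and a number 1.5 percentage points higher (within the scatter) from compound 3 to compound 4, 21.5 percentage points apart, beyond the scatter of two such steps. On the core of compound 3, the change from benzyl to 2-chlorobenzyl gives a number 1.5 percentage points higher from compound 3 to compound 4 (within the scatter), so no effect of the chloro can be read on this core, and the drop seen on the other core cannot be taken as general. With one pair per core, the data do not show which difference between the cores goes with the gap.

Open, going by these compounds, is whether the nitro and methoxy groups or the fluoro and bromo groups matter for this step. Also open, on these data alone, is how an amine or a carboxylic acid in place of the chloro would read on either core.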